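Swapping the Imidazole Ring for an Aminomethyl Group

A few compounds are considered here, and "the series" means these few. Any claim that something is new, unique, unknown or untested is made for them only; others in the source may bear on it.

Measured compounds:
compound 1: `O=C(Nc1cccc2c1CCCC2c1c[nH]cn1)C(F)(F)F` — 166 nM
compound 2: `CS(=O)(=O)Nc1ccc(O)c2c1CCCC2c1c[nH]cn1` — 708 nM
compound 3: `CCS(=O)(=O)Nc1cccc2c1CCCC2c1c[nH]c(C)n1` — 794 nM

All three measured compounds share a core in which a saturated six-membered ring is fused to an aromatic ring, and each carries an imidazole ring on the saturated ring. In an assay on isolated protein for binding affinity to Alpha-1A adrenergic receptor (Rattus norvegicus), read by radioligand binding (on this read-out higher numbers stand for weaker inhibition and lower numbers for stronger inhibition), compound 1 gives 166 nM, compound 2 gives 708 nM, and compound 3 gives 794 nM. Compound 3 has the highest number of the three; its gap to compound 2 is within the scatter, so those two cannot be ranked, while its gap to compound 1 is beyond the scatter, so compound 1 binds more tightly than compound 3.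

Compound 4, `CCS(=O)(=O)Nc1cccc2c1CCCC2CN`, differs from compound 3 in one place: aminomethyl in place of 2-methyl-1H-imidazol-4-yl on a saturated ring carbon. Every measured compound keeps an imidazole ring at this position, so nothing measured here shows what removing it does; the expectation below rests on that ring being the one constant feature of all three. The change is therefore expected to weaken binding by a step beyond the scatter. Compound 4 is estimated to give about 5000 nM in this assay, with a likely range from 1000 nM to 25000 nM. This would be an expected step of a 6.3-fold higher number from compound 3 to compound 4 (0.80 log units; beyond the scatter) toward weaker binding.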

Compound 4, inhibition constant: 794 nM
Estimate against measurement, compound 4: 6.3-fold (0.80 log units) above; measured number outside the range, below it.
By their numbers in this assay, from the lowest: compound 1; then compounds 2, 3 and 4 (each within the scatter of the next).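

Replacing 2-methyl-1H-imidazol-4-yl with aminomethyl on this saturated ring carbon gives, in this assay, no change at the digits printed from compound 3 to compound 4 (within the scatter). This is the only view shown of this position without an imidazole ring, and for this pair it means that the ring can be removed with no measurable loss: aminomethyl has no ring and fewer heavy atoms, yet compound 4 reads the same as compound 3. Nothing available here explains why these two different groups give the same reading.

The compounds shown leave open how much further this position can be varied, for example whether a longer chain such as aminoethyl, a dimethylaminomethyl group or a carboxylic acid would also keep the number unchanged or would shift it beyond the scatter. They also leave open whether the same swap would give the same result on the core of compound 1, where a trifluoroacetyl amide stands in place of the ethyl sulfonamide of compound 3.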